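The source may report more compounds than this note shows. Statements on the series, on what has been measured and on what is new or still open speak of the compounds shown alone.

Measured so far:
Compound 1, `CCCCCCCCCCC#Cc1cc2cn(C)c(=O)nc2o1`: in a functional assay on HEL cells (Homo sapiens) for cytotoxicity (a higher number here means that more compound is tolerated, a lower number that less compound is tolerated), compound 1 reaches only the limit > 150000 nM.
Compound 2, `CCCCCCCCCCC#Cc1cc2cn([C@H]3C[C@H](O)[C@@H](CO)O3)c(=O)nc2o1`: in this assay compound 2 gives 36000 nM.

Within the data shown here, compound 2 holds the only actual number in this assay; the other value is a limit, not a number, marked by the limit of > 150000 nM in this assay, at which 1 of the 2 values shown sits. Among the measured compounds shown here, the one measured step, an at least 4.1-fold lower number from compound 1 to compound 2 (0.61 log units; beyond the scatter), swaps the group on the aromatic nitrogen.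

Compound 3, `CCCCCCCCC#Cc1cc2cn([C@H]3C[C@H](O)[C@@H](CO)O3)c(=O)nc2o1`, keeps the sugar-like group of compound 2 and changes only the chain: hydrogen in place of ethyl on a saturated chain carbon, eight bonds along the chain from a triple-bonded carbon. For the measured compounds named here, no measured step touches this chain, so the step from compound 1 to compound 2 gives no direct guide. With nothing in the data pointing to a large shift, compound 3 is expected to stay within the scatter of compound 2, as a 1.4-fold higher number from compound 2 to compound 3 (0.14 log units; within the scatter). The estimate for compound 3 in this assay is 50000 nM, ranging from 18000 nM to 150000 nM.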

Compound 3, half-maximal cytotoxic concentration: 77000 nM
Estimate against measurement, compound 3: 1.5-fold (0.19 log units) below, and the stated range covers the measured number.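

The chain, which the earlier step left untouched, matters in this assay: hydrogen in place of ethyl on a saturated chain carbon, eight bonds along the chain from a triple-bonded carbon, gives a 2.1-fold higher number from compound 2 to compound 3 (0.33 log units; beyond the scatter), a modest change resting on one pair of compounds. The number therefore responds to this part of the chain as well as to the group on the aromatic nitrogen. Among these compounds, compound 1 still holds the only limit in the set, which is not a number and plays no part in this step: the limit of > 150000 nM in this assay, at which 1 of the 3 values shown sits.

Whether a longer chain would shift the number the opposite way cannot be told from two chain lengths. Nor do the compounds shown say how an amine or a carboxylic acid in place of the ethyl would compare.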